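Aryl oxime ether acids: paw edema, varying the para substituent

The source may hold more compounds than are shown below. What is called first, only, known or untested is meant among the compounds shown, and "the series" means these compounds.

Measured so far:
compound 1 `C/C(=N\OCC(=O)O)c1ccc(C(C)(C)C)cc1` — < 20% in a functional assay on the whole organism for inhibition, with Rattus norvegicus as the target, read by paw edema, with stated times of 1 h and 3 h, at a dose of 50 mg/kg by the oral route (a higher number here means more inhibition at the dose given (going by the name of the read-out), a lower number less inhibition), a limit of the assay.
compound 2 `C/C(=N\OCC(=O)O)c1ccc(CC2CCCCC2)cc1` — < 20% in this assay, likewise a limit.
compound 3 `C/C(=N\OCC(=O)O)c1ccc(O)cc1` — < 20% in this assay, likewise a limit.

Compound 3 thus sits at the limit, together with the two other values, as summarised by the limit of < 20% in this assay, at which 3 of the 3 values shown sit. Among the measured compounds shown here, no measured step is readable: a step that the two limits leave unreadable from compound 1 to compound 2, a step that the two limits leave unreadable from compound 1 to compound 3 and a step that the two limits leave unreadable from compound 2 to compound 3 are all left unreadable by the two limits. Compound 4 `CSc1ccc(/C(C)=N/OCC(=O)O)cc1` differs from compound 3 as follows: methylsulfanyl in place of hydroxy on an aromatic carbon. The two steps ending at compound 3 change the same aromatic carbon but give no size, so nothing measured bears on this change. The step from compound 3 to compound 4 is therefore expected to be a step that the limit leaves unreadable from compound 3 to compound 4, no change beyond the scatter. Compound 4 is estimated to give 15%, between 0% and 35%.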

Compound 4, a percentage reported as inhibition, in the whole organism at one dose (the size of the read-out at that dose, not a potency): < 20%
Compound 4: a limit, no number; the forecaster's own chance of this, stated with the estimate: 60%; the middle value is on the limit's open side.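

Among the compounds shown here, no step from compound 1, compound 2 or compound 3 to compound 4 can be read in this assay, as all four stand at one limit: the limit of < 20% in this assay, at which 4 of the 4 values shown sit.

The compounds shown leave open whether any group on this aromatic carbon gives inhibition clear of that limit, and how far these four compounds differ.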